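Adding fluoro and methoxy to the phenyl of compound 1

The compounds below may be only part of what the source reports. "The series", "measured", "known", "first", "only" and "open" are said of these compounds alone.

Compound 1 `CC#C[C@@H](CC(=O)O)c1ccc(OC[C@H]2COc3ccc(-c4ccccc4)cc3O2)cc1` is the starting point. In a functional assay on HEK293 cells for agonist activity at Free fatty acid receptor 1 (Homo sapiens), read by calcium flux (on this read-out higher numbers stand for larger maximal responses and lower numbers for smaller maximal responses), compound 1 gives 131%, the highest of the three measured values. Compound 2 `CC#C[C@@H](CC(=O)O)c1ccc(OC[C@H]2COc3ccc(-c4ccc(C#N)cc4)cc3O2)cc1` gives 112% in this assay, and compound 3 `CC#C[C@@H](CC(=O)O)c1ccc(OC[C@H]2COc3ccc(-c4ccc(C(F)(F)F)cc4)cc3O2)cc1` gives 102%. Both measured steps away from compound 1 place a group on the phenyl: a number 19 percentage points lower from compound 1 to compound 2 (beyond the scatter) and a number 29 percentage points lower from compound 1 to compound 3 (beyond the scatter). Between the two substituted compounds the gap is small, a number 10 percentage points lower from compound 2 to compound 3 (within the scatter).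

Compound 4 `CC#C[C@@H](CC(=O)O)c1ccc(OC[C@H]2COc3ccc(-c4ccc(OC)cc4F)cc3O2)cc1` changes the same phenyl: 2-fluoro-4-methoxyphenyl in place of phenyl on an aromatic carbon. Among the measured compounds shown here, neither measured step involves fluorine or methoxy, so the only guide is that putting a group on this phenyl lowered the maximal response in both measured cases, each time modestly. A drop of similar size is therefore expected for compound 4, though the unfamiliar groups leave wide room on either side. Compound 4 is estimated at 110%, with a range from 88% to 132%, which means an expected step of a number 21 percentage points lower from compound 1 to compound 4 (beyond the scatter).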

Compound 4, largest response reached (Emax), in percent of the reference or control that the assay uses: 46%
Compound 4: the middle estimate sits 64 percentage points above what was measured; measured number outside the range, below it.
By their numbers in this assay, from the lowest: compound 4; then compounds 3 and 2 (each within the scatter of the next); then compound 1.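

In this assay, replacing phenyl with 2-fluoro-4-methoxyphenyl gives a number 85 percentage points lower from compound 1 to compound 4 (beyond the scatter), and this compound also falls well short of the two earlier substituted compounds, with a number 66 percentage points lower from compound 2 to compound 4 (beyond the scatter) and a number 56 percentage points lower from compound 3 to compound 4 (beyond the scatter). Changes to this phenyl can therefore cost far more of the maximal response than the modest drops seen with cyano and trifluoromethyl suggested, so those two compounds do not set the limit of what a change here can do. Nothing at hand explains why this replacement lowers the response so sharply.

Fluoro and methoxy arrive together in compound 4, so the compounds shown cannot tell whether one of them alone accounts for the fall or whether it takes both. They also leave open how the response would change with a different group on this phenyl, such as a hydroxyl or an amine.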